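The compounds below may be only part of what the source reports. "The series", "measured", "known", "first", "only" and "open" are said of these compounds alone.

Measured compounds, with their values in a functional assay on HT-29 cells (Homo sapiens) for cytotoxicity, read by sulforhodamine B assay, with a stated time of 48 h; a higher number here means a weaker inhibitor, a lower number a stronger inhibitor:

Compound 1, `Cc1ccccc1OS(=O)(=O)c1cccc(NC(=O)NCCCCl)c1`: 21000 nM
Compound 2, `CCc1ccccc1OS(=O)(=O)c1cccc(NC(=O)NCCCCl)c1`: 23000 nM
Compound 3, `Cc1ccccc1NS(=O)(=O)c1cccc(NC(=O)NCCCCl)c1`: 42000 nM

All three compounds share a core that carries a sulfonyl group and a chloropropyl urea; they differ only at the sulfonyl sulfur and at the aryl group attached there. Compound 1 and compound 2 are separated by methyl in place of hydrogen on a saturated chain carbon bound to an aromatic carbon, and in this assay this gave a 1.1-fold higher number from compound 1 to compound 2 (0.04 log units; within the scatter). Compound 1 and compound 3 differ in the core itself, namely ((2-methylphenyl)amino in place of 2-methylphenoxy on a sulfonyl sulfur), and that change gave a 2.0-fold higher number from compound 1 to compound 3 (0.30 log units; within the scatter). Compound 3 thus shows the highest of the three numbers, but its gaps to compound 1 and compound 2 are both within the scatter, so no order among the three can be drawn.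

Compound 4, `CCc1ccccc1NS(=O)(=O)c1cccc(NC(=O)NCCCCl)c1`, has not yet been measured. It relates to compound 3 in the same way that compound 2 relates to compound 1: the difference is methyl in place of hydrogen on a saturated chain carbon bound to an aromatic carbon, made at a place described in the same words in both pairs, so it is the same change on a different core. Since this change gave a 1.1-fold higher number from compound 1 to compound 2 (0.04 log units; within the scatter), the expectation for compound 3 to compound 4 is a step of similar size, namely a 1.1-fold higher number from compound 3 to compound 4 (0.04 log units; within the scatter). This expectation rests on a single prior pair, so it is held loosely. On that basis compound 4 is expected to give about 46000 nM, with a plausible range from 24000 nM to 90000 nM.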

Compound 4, half-maximal inhibitory concentration: 96000 nM
Compound 4: middle estimate off by 2.1-fold (0.32 log units), on the low side; the measured number lies above the stated range.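

In this assay, methyl in place of hydrogen on a saturated chain carbon bound to an aromatic carbon gives a 2.3-fold higher number from compound 3 to compound 4 (0.36 log units; beyond the scatter), a modest step, and it now stands beside the step made by the same change on the core of compound 1: the same change on two cores in this assay, a 1.1-fold higher number (0.04 log units; within the scatter) from compound 1 to compound 2 and a 2.3-fold higher number (0.36 log units; beyond the scatter) from compound 3 to compound 4, 2.1-fold (0.32 log units) apart, within the scatter of two such steps. Within the data shown here, although only the step on the core of compound 3 lies beyond the scatter, the gap between the two steps lies within it, so these pairs do not show that the change acts differently on the two cores. Nor do they prove that it carries over unchanged, since the comparison rests on one pair for each of two cores, and the change from methyl to ethyl can be followed no further than that.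

The compounds shown leave open whether a longer chain such as propyl, or a branched group such as isopropyl, in place of ethyl would extend the step on either core. From the compounds shown here alone, all four compounds also keep the chloropropyl urea, so it remains open whether the steps would look the same with a chloroethyl chain there.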